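The compounds below may be only part of what the source reports. "The series", "measured", "known", "first", "only" and "open" are said of these compounds alone.

Measured so far in an ADME assay on microsomes from liver (Mus musculus) for pharmacokinetics; a higher number here means faster removal of the compound, a lower number slower removal:

- Compound 1 `C[C@H](NC(=O)[C@@H]1CCCN1C)c1ccc(NC(=O)[C@H]2C[C@@H]2c2cccnc2)cc1`: 65.4 mL.min-1.g-1
- Compound 2 `C[C@H](NC(=O)c1ccccc1)c1ccc(NC(=O)[C@H]2C[C@@H]2c2cccnc2)cc1`: 148 mL.min-1.g-1
- Compound 3 `C[C@H](NC(=O)c1ccc(C#N)cc1)c1ccc(NC(=O)[C@H]2C[C@@H]2c2cccnc2)cc1`: 53 mL.min-1.g-1

On these numbers, compound 3 cannot be told apart from compound 1: a 1.2-fold lower number from compound 1 to compound 3 (0.09 log units; within the scatter). Both stand clear of compound 2, as a 2.3-fold higher number from compound 1 to compound 2 (0.35 log units; beyond the scatter) and a 2.8-fold lower number from compound 2 to compound 3 (0.45 log units; beyond the scatter) show.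

The next structure is compound 4 `C[C@H](NC(=O)c1ncccn1)c1ccc(NC(=O)[C@H]2C[C@@H]2c2cccnc2)cc1`. The change is pyrimidin-2-yl in place of 4-cyanophenyl on a carbonyl carbon, with pyrimidin-2-yl in place of 4-cyanophenyl on a carbonyl carbon.

Among the measured compounds shown here, no measured step makes this exact swap, so the evidence is indirect. All three measured steps alter the group on this carbonyl, and the largest, a 2.8-fold lower number from compound 2 to compound 3 (0.45 log units; beyond the scatter), is only modest. For the measured compounds named here, compound 2, with its plain phenyl, gives the one high number at 148 mL.min-1.g-1, whereas the two differing groups in compound 1 and compound 3 give numbers within the scatter of each other. Compound 4 also lacks the plain phenyl, so it is expected to stay near compound 3 rather than move towards compound 2.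

The expected change is small, slightly downward if anything: a 1.2-fold lower number from compound 3 to compound 4 (0.07 log units; within the scatter). For compound 4 the estimated value in this assay is 45 mL.min-1.g-1, with an expected range from 20 mL.min-1.g-1 to 105 mL.min-1.g-1.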

Compound 4, intrinsic clearance in microsomes: 38.4 mL.min-1.g-1
Compound 4: middle estimate off by 1.2-fold (0.07 log units), on the high side; measured number inside the range.
By their numbers in this assay, from the lowest: compounds 4, 3 and 1 (each within the scatter of the next); then compound 2.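

Pyrimidin-2-yl can take the place of 4-cyanophenyl on this carbonyl carbon with no change that stands out from the scatter in this assay: a 1.4-fold lower number from compound 3 to compound 4 (0.14 log units; within the scatter). The ring that enters has nitrogen in it and no nitrile, yet compound 4 also cannot be told apart from the compound carrying 1-methylpyrrolidin-2-yl, a 1.7-fold lower number from compound 1 to compound 4 (0.23 log units; within the scatter), while it stands well clear of the plain phenyl, a 3.9-fold lower number from compound 2 to compound 4 (0.59 log units; beyond the scatter). Among these four compounds, three quite different groups on this carbonyl now fall together and only compound 2 stands apart, though nothing measured here says what sets its plain phenyl apart from the other three groups.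

Going by these compounds, all four compounds share the rest of their structure, so it remains open whether this grouping would hold if the core were changed elsewhere. On these data alone, it is also open whether groups of another kind on this carbonyl, such as a carboxylic acid, an open-chain amine or a longer carbon chain, would join the three compounds with the lower numbers or move towards compound 2.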